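A few compounds are considered here, and "the series" means these few. Any claim that something is new, unique, unknown or untested is made for them only; others in the source may bear on it.

Measured in a functional assay on OVCAR-3 cells (Homo sapiens) for cytotoxicity, read by sulforhodamine B assay; a lower number here means that less compound is tolerated, a higher number that more compound is tolerated:
- compound 1 `CC1=CC[C@@H]([C@@](C)(O)CCCC(C)(C)NC(=S)N/N=C\c2ccc(C)cc2)CC1`: 45300 nM
- compound 2 `CC1=CC[C@@H]([C@@](C)(O)CCCC(C)(C)NC(=S)N/N=C\c2ccccc2[N+](=O)[O-])CC1`: 41900 nM

Within the data shown here, compound 2 stands level with compound 1, the only other measured compound, and the two values cannot be separated. Compound 3 `CC1=CC[C@@H]([C@@](C)(O)CCCC(C)(C)NC(=S)N/N=C\c2cccc(Cl)c2)CC1` changes the same place again: 3-chlorophenyl in place of 2-nitrophenyl on a carbon with a double bond to nitrogen. Among the measured compounds shown here, one measured step bears on this, the exchange of 4-methylphenyl for 2-nitrophenyl at that place, which gave a 1.1-fold lower number from compound 1 to compound 2 (0.03 log units; within the scatter). For the measured compounds named here, with only this step as a guide, no change beyond the scatter is expected in this assay, and the estimated step is a 1.0-fold lower number from compound 2 to compound 3 (0.02 log units; within the scatter). The expected value for compound 3 is 40000 nM, with a range of 22000 nM to 70000 nM.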

Compound 3, concentration lethal to 50% of the cells: 48000 nM
Compound 3: middle estimate off by 1.2-fold (0.08 log units), on the low side; the range from low to high includes it.
By their numbers in this assay, from the lowest: compounds 2, 1 and 3 (each within the scatter of the next).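

In this assay, 3-chlorophenyl in place of 2-nitrophenyl on the carbon with a double bond to nitrogen gives a 1.1-fold higher number from compound 2 to compound 3 (0.06 log units; within the scatter), and 3-chlorophenyl in place of 4-methylphenyl gives a 1.1-fold higher number from compound 1 to compound 3 (0.03 log units; within the scatter). This assay therefore does not separate the three groups at this place, even though 3-chlorophenyl carries chlorine and lacks the two hydrogen-bond acceptors of 2-nitrophenyl. No evidence on the reason for this is available. From the compounds shown here alone, it remains open whether a phenyl ring carrying an amine or a carboxylic acid at this place would give a step beyond the scatter.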